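Second Chloro Group on the Aryl Ring of Compound 3

The source may report more compounds than this note shows. Statements on the series, on what has been measured and on what is new or still open speak of the compounds shown alone.

Measured compounds:
compound 1, `N#C/C(=C\N1CCN(C(=O)c2ccco2)C1=S)C(=O)Nc1ccc(Cl)cc1`: 17400 nM
compound 2, `N#C/C(=C\N1CCN(C(=O)c2ccco2)C1=S)C(=O)c1ccccc1`: 16100 nM
compound 3, `O=CN1CCN(c2ccc(Cl)cc2)C1=S`: 6800 nM

All three were tested in a functional assay on 786-0 cells (Homo sapiens) for inhibition, read by sulforhodamine B assay, with a stated time of 48 h; a lower number here means a stronger inhibitor of growth, a higher number a weaker inhibitor of growth. Compound 3 gives the lowest number and is the strongest growth inhibitor of the three; compound 2 gives 16100 nM and compound 1 gives 17400 nM, both beyond the scatter from compound 3.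

Compound 4, `O=CN1CCN(c2ccc(Cl)c(Cl)c2)C1=S`, differs from compound 3 by chloro in place of hydrogen on an aromatic carbon. Within the data shown here, the only measured step, a 1.1-fold lower number from compound 1 to compound 2 (0.03 log units; within the scatter), concerns a different change on a different pair and says nothing about adding a chloro group. Among the measured compounds shown here, no step bears on this change. The step of a 1.0-fold lower number from compound 3 to compound 4 (0.02 log units; within the scatter) is therefore expected to stay within the scatter, with a wide range. Compound 4 is expected to give 6500 nM, between 2500 nM and 18000 nM.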

Compound 4, concentration for 50% growth inhibition: 4500 nM
Beside the measured number, compound 4's estimate is 1.4-fold (0.16 log units) above it; the range from low to high includes it.
By their numbers in this assay, from the lowest: compounds 4 and 3 (each within the scatter of the next); then compounds 2 and 1 (each within the scatter of the next).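

In this assay, a chloro group in place of hydrogen, ortho to the chloro group already on the aromatic ring, gives a 1.5-fold lower number from compound 3 to compound 4 (0.18 log units; within the scatter). Among these compounds, this is the first reading on that ring, and it shows that the ring can carry a second chloro group there while growth inhibition stays within the scatter. No measurement here offers a reason for this result.

As far as these compounds go, whether a different group at this place, such as an amine, a methoxy group or a carboxylic acid, would move the number beyond the scatter remains open.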